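Placing a Larger Aromatic Group Where Fluorine Stood

A few compounds are considered here, and "the series" means these few. Any claim that something is new, unique, unknown or untested is made for them only; others in the source may bear on it.

Measured so far:
compound 1: `Cc1cccc(Oc2cccc(COc3ccccc3CCC(=O)OCCCOP(=O)(O)OC[C@H](N)C(=O)O)c2)c1` — 21.3%
compound 2: `N[C@@H](COP(=O)(O)OCCCOC(=O)CCc1ccccc1OCc1cccc(Oc2ccc(F)cc2)c1)C(=O)O` — 18.7%

Both numbers come from an assay on cells for agonist activity at probable G-protein coupled receptor 34 (Mus musculus), with a stated time of 1 h; a lower number here means a smaller maximal response, a higher number a larger maximal response. Among the measured compounds shown here, compound 2 stands at the low end of the two, yet compound 1 lies within the scatter of it; the only measured step, a number 2.6 percentage points lower from compound 1 to compound 2 (within the scatter), is therefore small and tells little about what follows. Compound 3 (`Cc1ccccc1-c1ccc(Oc2cccc(COc3ccccc3CCC(=O)OCCCOP(=O)(O)OC[C@H](N)C(=O)O)c2)cc1`) differs from compound 2 in that (2-methylphenyl in place of fluoro on an aromatic carbon). For the measured compounds named here, no measured step shows a group of this kind entering at this place, so the expected step of a number 3.3 percentage points higher from compound 2 to compound 3 (within the scatter) is none beyond the scatter, with wide uncertainty. Compound 3 is estimated at 22%, between 8% and 40%.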

Compound 3, largest response reached (Emax), in percent of the reference or control that the assay uses: 13.4%
The estimate for compound 3 lay 8.6 percentage points above the measured number; the range from low to high includes it.
By their numbers in this assay, from the lowest: compounds 3, 2 and 1 (each within the scatter of the next).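

In this assay, putting 2-methylphenyl where fluoro stood gives a number 5.3 percentage points lower from compound 2 to compound 3 (within the scatter), so a single fluorine and a much larger group carrying its own aromatic ring cannot be told apart at this place. The earlier compounds shown here did not test a group of this size here. No available evidence bears on this result. From the compounds shown here alone, a hydroxyl, an amine or a carboxylic acid at the same aromatic carbon remains open, as does whether any group here can give a step beyond the scatter.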